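Removing the Benzoyl Group from Compound 1

The source may report more compounds than this note shows. Statements on the series, on what has been measured and on what is new or still open speak of the compounds shown alone.

compound 1 `O=C(O[C@H]1C[C@H](n2cc(F)c(=O)[nH]c2=O)O[C@@H]1COP(=O)(O)Oc1ccc2ncccc2c1)c1ccccc1` gives 7300 nM
compound 2 `CCOC(=O)C[n+]1cccc2cc(OP(=O)([O-])OC[C@H]3O[C@@H](n4cc(F)c(=O)[nH]c4=O)C[C@@H]3OC(=O)c3ccccc3)ccc21` gives 600 nM

Of the compounds shown here, two have been measured so far. In a functional assay on HeLa cells (Homo sapiens) for cytotoxicity, read by MTT assay, with a stated time of 48 h (a higher number here means a weaker inhibitor, a lower number a stronger inhibitor), compound 1 gives 7300 nM and holds the higher of the two numbers. Compound 2 gives 600 nM in the same test, and the gap between the two lies beyond the usual scatter.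

The next compound to be tested is compound 3 `O=c1[nH]c(=O)n([C@H]2C[C@H](O)[C@@H](COP(=O)(O)Oc3ccc4ncccc4c3)O2)cc1F`, which departs from compound 1 in a single place: hydrogen in place of benzoyl on an oxygen on a saturated carbon. Put simply, hydrogen stands in place of benzoyl on an oxygen on a saturated carbon, so that benzoyloxy becomes hydroxy.

Within the data shown here, no measured pair shows this change, and the data therefore offer no direct guide to its size. In this assay a modest step toward a lower number is expected, one that may not clearly exceed the scatter. The expected move is a 1.8-fold lower number from compound 1 to compound 3 (0.26 log units; within the scatter) on this estimate, with wide uncertainty in both directions. Compound 3 is estimated at 4000 nM with an expected range from 800 nM to 20000 nM as its likely span.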

Compound 3, half-maximal inhibitory concentration: 7300 nM
Compound 3: middle estimate off by 1.8-fold (0.26 log units), on the low side; measured number inside the range.
By their numbers in this assay, from the lowest: compound 2; then compounds 1 and 3 (each within the scatter of the next).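

In this assay, hydrogen in place of benzoyl on an oxygen on a saturated carbon gives no change at the digits printed from compound 1 to compound 3 (within the scatter). Among these compounds, this is the first reading at this position, and it shows that benzoyloxy and hydroxy cannot be told apart in this test, even though the change removes the whole benzoyl group, with its six-membered aromatic ring of carbon only and its hydrogen-bond acceptor. The data offer nothing that accounts for this result.

The compounds shown leave open whether other groups on this oxygen, such as acetyl, a longer acyl chain, or an acyl group carrying an amine or a carboxylic acid, would also stay within the scatter of compound 1 and compound 3. They also leave open whether the same change of benzoyloxy to hydroxy would behave in the same way on compound 2, which gives 600 nM in this assay, as it does on compound 1.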